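Compound 2 and Its Carbamoyl Analogue

The compounds below may be only part of what the source reports. "The series", "measured", "known", "first", "only" and "open" are said of these compounds alone.

In a functional assay on the whole organism (stomach) for inhibition, with Rattus norvegicus as the target, at a dose of 100 mg/kg by the intraduodenal route (on this read-out higher numbers stand for more inhibition at the one dose given (going by the name of the read-out) and lower numbers for less inhibition), three compounds have been measured. Compound 1 `CC(Cn1ncccc1=O)C(=N)S` gives 40.3%, compound 3 `N=C(S)CCn1ncccc1=S` gives 50%, and compound 2 `C/N=C(\S)CCn1nc(-c2ccccc2)ccc1=O` gives 68.2%, the highest of the three; compound 3 stands nearest to it and compound 1 furthest, and both gaps lie beyond the scatter. Compound 4 `NC(=O)CCn1nc(-c2ccccc2)ccc1=O` has not been measured in this assay. It differs from compound 2 in one place: a group of 3 heavy atoms (1 carbon, 1 nitrogen, 1 oxygen; no ring) in place of a group of 4 heavy atoms (2 carbon, 1 nitrogen, 1 sulfur; no ring), on a saturated chain carbon, two bonds along the chain from an aromatic nitrogen. Within the data shown here, no measured pair shows this change, so nothing directly tells its effect, and every measured compound keeps the sulfur-bearing group that compound 4 gives up. The step is expected to go downward, beyond the scatter, at a number 28.2 percentage points lower from compound 2 to compound 4 (beyond the scatter). Compound 4 is therefore estimated at 40%, within 15% to 65%.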

Compound 4, a percentage reported as inhibition, in the whole organism at one dose (the size of the read-out at that dose, not a potency): -2.8%
Compound 4: middle estimate off by 42.8 percentage points, on the high side, and the stated range ends above it.
By their numbers in this assay, from the lowest: compound 4; then compounds 1 and 3 (each within the scatter of the next); then compound 2.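

In this assay, this position proves highly sensitive: placing carbamoyl on the saturated chain carbon gives a number 71 percentage points lower from compound 2 to compound 4 (beyond the scatter), so the inhibition seen for compound 2 depends on the group at this place. The two groups have the same counts of hydrogen-bond donors and acceptors, so those counts do not separate them. No evidence at hand bears on the reason for this drop. The compounds shown leave open whether the loss follows the sulfur, the extra carbon or both, since the change alters them together. From the compounds shown here alone, how a carboxylic acid or a longer chain would read at this place also remains open.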